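The source may report more compounds than this note shows. Statements on the series, on what has been measured and on what is new or still open speak of the compounds shown alone.

Values measured in a functional assay on MCF7 cells (Homo sapiens) for inhibition, read by CCK-8 assay, with a stated time of 48 h; a higher number here means a weaker inhibitor, a lower number a stronger inhibitor:
- compound 1 `COc1cc(-c2cc3nccc(-c4c[nH]c5ccccc45)n3n2)cc(OC)c1OC`: > 10000 nM, a limit of the assay and not a number
- compound 2 `Cn1ccc2cc(-c3cc4nccc(-c5ccc(F)cc5)n4n3)ccc21`: 4580 nM
- compound 3 `COc1cc(-c2ccnc3cc(-c4ccc5c(ccn5C)c4)nn23)cc(OC)c1OC`: 3 nM

Compound 3 holds the lowest number of the set at 3 nM. Its nearest neighbour is compound 2 at 4580 nM, a gap well beyond the scatter of repeated measurements. Compound 1 gives no number to compare, only a limit.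

The next compound to be tested is compound 4 `COc1cc(-c2ccnc3cc(-c4cccc(C)c4)nn23)cc(OC)c1OC`. It keeps the rest of compound 3 but has 3-methylphenyl in place of 1-methyl-1H-indol-5-yl on an aromatic carbon.

For the measured compounds named here, no two measured compounds differ in just one place, so no measured step shows what this swap does, and any forecast is uncertain. Still, compound 3 sits so low, at 3 nM, that a change of this size seems far more likely to raise the number than to lower it. A rise beyond the scatter is therefore expected in this assay, meaning a weaker inhibitor. The expected size of the change is a 100-fold higher number from compound 3 to compound 4 (2.00 log units; beyond the scatter).

For compound 4 the estimate is 300 nM, with an expected range from 25 nM to 4000 nM.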

Compound 4, half-maximal inhibitory concentration: 1080 nM
The estimate for compound 4 lay 3.6-fold (0.56 log units) below the measured number; the range from low to high includes it.
By their numbers in this assay, from the lowest: compound 3; then compound 4; then compound 2. At a limit, above all of these: compound 1.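

In this assay, replacing 1-methyl-1H-indol-5-yl with 3-methylphenyl on this aromatic carbon, with the rest of the molecule unchanged, gives a 360-fold higher number from compound 3 to compound 4 (2.56 log units; beyond the scatter). The earlier compounds shown here could not show this, as they differ from one another in more than one place, whereas this single swap shows that the group at this position has a large effect on the measured inhibition of these cells: the two-ring 1-methyl-1H-indol-5-yl gives by far the lower number, and the one-ring 3-methylphenyl gives the higher one. Nothing in the data shown accounts for the size of this step.

The swap removes the five-membered ring and its nitrogen together and also brings in a methyl group on the six-membered ring, so the compounds shown leave open which of these differences matters most. A plain phenyl group, or a phenyl ring carrying an amine in place of the methyl, would help separate these differences.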